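The source may hold more compounds than are shown below. What is called first, only, known or untested is meant among the compounds shown, and "the series" means these compounds.

Measured compounds in an assay on membranes from Sf9 cells for displacement of a labelled ligand from histamine H2 receptor (Homo sapiens), read by scintillation counting, with a stated time of 60 min; on this read-out higher numbers stand for weaker inhibition and lower numbers for stronger inhibition:
Compound 1, `CCCCCNC(=O)/N=C(\N)NCCCc1sc(N)nc1C`, gives 4.47 nM.
Compound 2, `Cc1nc(N)sc1CCCN/C(N)=N/C(=O)NC(C)c1ccccc1F`, gives 28.8 nM.
Compound 3, `Cc1nc(N)sc1CCCN/C(N)=N/C(=O)NC(c1ccccc1)c1ccccc1`, gives 43.7 nM.

Among these three numbers compound 1 stands lowest, and its gap to compound 2 and to compound 3 lies beyond the usual scatter, so it is the strongest inhibitor of the three. Compound 4, `Cc1nc(N)sc1CCCN/C(N)=N/C(=O)NCc1ccco1`, has not yet been measured. It differs from compound 1 in one place: furan-2-yl in place of butyl on a saturated chain carbon bound to an amide-type nitrogen. Going by the values given here, no step between two measured compounds covers exactly this exchange, so the direction has to be read from compound 2 with 28.8 nM and compound 3 with 43.7 nM, which both carry a ring on the saturated chain carbon bound to the amide-type nitrogen and both give higher numbers than compound 1. On that basis compound 4 is expected to sit above compound 1, with an estimated step of a 2.7-fold higher number from compound 1 to compound 4 (0.43 log units; beyond the scatter) that is modest but beyond the scatter. The estimate for compound 4 in this assay is 12 nM, within a range from 4 nM to 35 nM.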

Compound 4, inhibition constant: 10.5 nM
The estimate for compound 4 lay 1.1-fold (0.06 log units) above the measured number; the measured number falls inside the stated range.
By their numbers in this assay, from the lowest: compound 1; then compound 4; then compounds 2 and 3 (each within the scatter of the next).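

Going by these compounds alone, with furan-2-yl in place of butyl on a saturated chain carbon bound to an amide-type nitrogen, this assay records a 2.3-fold higher number from compound 1 to compound 4 (0.37 log units; beyond the scatter), the first direct reading of this exact exchange. A five-membered aromatic ring with one hetero atom is therefore tolerated at this place at a modest cost: the number rises beyond the scatter, yet compound 4 still gives 10.5 nM in this series. Nothing measured here explains the step.

The compounds shown leave open whether thiophen-2-yl, with sulfur in the ring in place of oxygen, would behave like furan-2-yl at this place, and whether a chain longer than butyl, such as hexyl, would raise or lower the number. They also cannot show whether the same exchange would give a similar step on a different core.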